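From cyclobutyl to 3-fluorooxetan-3-yl

The compounds below may be only part of what the source reports. "The series", "measured", "known", "first", "only" and "open" are said of these compounds alone.

In a physicochemical assay for lipophilicity, at pH 7.4 (a lower number here means a more polar compound, a higher number a more lipophilic compound), compound 2 `Fc1ccc(OCc2cc(OCC3CCC3)nc(-c3ccccn3)n2)c(F)c1F` stands highest at 4.5, while compound 1 `Fc1ccc(OCc2cc(N3CC4(CCO4)C3)nc(-c3ccccn3)n2)c(F)c1F` gives 3.3. Compound 3 `Fc1ccc(OCc2cc(OCC3(F)COC3)nc(-c3ccccn3)n2)c(F)c1F` carries 3-fluorooxetan-3-yl in place of cyclobutyl on a saturated chain carbon bound to an oxygen on an aromatic ring: 3-fluorooxetan-3-yl in place of cyclobutyl, on a saturated chain carbon bound to an oxygen on an aromatic ring. Within the data shown here, only one measured step bears on this, and only loosely: a number 1.20 log units higher from compound 1 to compound 2 (beyond the scatter), a large change that ended with a carbon-only four-membered ring. Here such a ring leaves and one with a hetero atom enters, so a fall of similar size is expected in this assay. The expected change is a number 1.10 log units lower from compound 2 to compound 3 (beyond the scatter). The estimate for compound 3 is 3.4, with a range of 2.9 to 3.9.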

Compound 3, distribution coefficient: 4
Compound 3: middle estimate off by 0.60 log units, on the low side; measured number outside the range, above it.
By their numbers in this assay, from the lowest: compound 1; then compound 3; then compound 2.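

At this position, the change from cyclobutyl to 3-fluorooxetan-3-yl gives a number 0.50 log units lower from compound 2 to compound 3 (beyond the scatter) in this assay. The group on the aromatic carbon also matters: a number 0.70 log units higher from compound 1 to compound 3 (beyond the scatter) even though a four-membered ring with a hetero atom stands on both sides of that step, so the presence of such a ring does not alone set the number. No measurement available here explains the size of either step.

Going by these compounds, the separate shares of the ring oxygen and the fluorine remain open. Oxetan-3-yl without fluorine and 3-fluorocyclobutyl on the same chain carbon would divide the step between them.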